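A few compounds are considered here, and "the series" means these few. Any claim that something is new, unique, unknown or untested is made for them only; others in the source may bear on it.

Compound 1 `Cc1cc(O)c(C(=O)/C=C/c2ccc(Cl)cc2)c(-c2ccc(Br)cc2)c1C(=O)/C=C/c1ccc(Cl)cc1` gives 32000 nM in a functional assay on HeLa cells (Homo sapiens) for cytotoxicity, read by MTT assay, with a stated time of 24 h; a lower number here means a stronger inhibitor, a higher number a weaker inhibitor. Compound 2 `Cc1cc(O)c(C(=O)/C=C/c2ccc(Cl)cc2)c(-c2ccc(OCc3ccccc3)cc2)c1C(=O)/C=C/c1ccc(Cl)cc1` is recorded in this assay as "not active" (no number reported), so compound 2 stands without a single number in this assay. Compound 3 `Cc1cc(O)c(C(=O)/C=C/c2ccc(Cl)cc2)c(-c2ccc(Cl)cc2)c1C(=O)/C=C/c1ccc(Cl)cc1` is not yet measured. From compound 2 to compound 3 the change is chloro in place of benzyloxy on an aromatic carbon. With no number for compound 2, the size of the step cannot be stated; the chloro analogue is expected to return to a measurable value near that of compound 1, since compound 1 gives 32000 nM. Compound 3 is estimated at 35000 nM, with a range from 12000 nM to 120000 nM.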

Compound 3, half-maximal inhibitory concentration: "not active" (no number reported)
Nothing numeric was reported for compound 3; no gap can be computed for the estimate.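

No step can be read from compound 2 to compound 3, as both are recorded as "not active" without a number in this assay; no supporting data bear on this result. The compounds shown leave open how far either lies from compound 1 at 32000 nM in potency.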